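The compounds below may be only part of what the source reports. "The series", "measured", "known", "first", "only" and "open" are said of these compounds alone.

Compound 1, `O=c1cc(-c2ccccc2)oc2cc(OCCCCNc3nc4ccccc4s3)cc(O)c12`: 48.5 ug/mL
Compound 2, `O=c1cc(-c2ccccc2)oc2cc(OCCCCNc3nc4ccc([N+](=O)[O-])cc4s3)cc(O)c12`: 41.4 ug/mL
Compound 3, `O=c1cc(-c2ccccc2)oc2cc(OCCCCNc3nc4ccc(I)cc4s3)cc(O)c12`: 56.4 ug/mL

These three compounds share one core and differ only in the group carried on one aromatic carbon of the 1,3-benzothiazol-2-yl part: hydrogen, nitro or iodo. All were tested in a functional assay on SK-OV-3 cells (Homo sapiens) for cytotoxicity, read by sulforhodamine B assay, with a stated time of 48 h; on this read-out lower numbers stand for stronger inhibition and higher numbers for weaker inhibition. Compound 3 sits at the top end of the three numbers, but its distance from the others is small: a 1.2-fold higher number from compound 1 to compound 3 (0.07 log units; within the scatter), and a 1.4-fold higher number from compound 2 to compound 3 (0.13 log units; within the scatter). Likewise a 1.2-fold lower number from compound 1 to compound 2 (0.07 log units; within the scatter). None of these steps leaves the scatter, so on these data the three compounds cannot be told apart.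

Compound 4, `O=c1cc(-c2ccccc2)oc2cc(OCCCCNc3nc4ccc(F)cc4s3)cc(O)c12`, is compound 3 with a single change: fluoro in place of iodo on an aromatic carbon. Among the compounds with values here, the steps that bear on this are the three just given, each a swap of the group on the same aromatic carbon, and each within the scatter. Hydrogen, nitro and iodo at that position gave numbers that differ by less than the scatter, so a fluoro group there is expected to do the same: a 1.1-fold lower number from compound 3 to compound 4 (0.05 log units; within the scatter), with no step beyond the scatter expected in this assay. Compound 4 is therefore estimated at 50 ug/mL, with a range from 30 ug/mL to 85 ug/mL.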

Compound 4, half-maximal inhibitory concentration: 33.7 ug/mL
The estimate for compound 4 lay 1.5-fold (0.17 log units) above the measured number; the measured number falls inside the stated range.
By their numbers in this assay, from the lowest: compounds 4, 2, 1 and 3 (each within the scatter of the next).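

Fluoro is a fourth group on this aromatic carbon in this assay, and it cannot be told apart from iodo (a 1.7-fold lower number from compound 3 to compound 4 (0.22 log units; within the scatter)), nitro (a 1.2-fold lower number from compound 2 to compound 4 (0.09 log units; within the scatter)) or hydrogen (a 1.4-fold lower number from compound 1 to compound 4 (0.16 log units; within the scatter)). The step from iodo to fluoro is the largest of all the steps at this position, yet it still stays within the scatter, so these four groups on the 1,3-benzothiazol-2-yl part give numbers that cannot be separated. Nothing available explains why the four numbers stay so close together.

The compounds shown leave open whether a different kind of group at this place, such as an amine, a carboxylic acid or a methoxy group, would give a step beyond the scatter. They also leave open whether a change elsewhere in the molecule, such as a longer chain between the shared core and the amino group, would move the number more than any swap on this aromatic carbon has done.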